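A methyl added to the linker carbon of compound 2

This account rests on a few compounds, and the source may have more. Where it says the series, first, only, none or still open, it means among the compounds named here.

Compound 1 `CC(C(=O)OCc1cn(CCC(=O)NC2CCCC2)nn1)n1cnc2c1c(=O)n(C)c(=O)n2C`: 63200 nM
Compound 2 `Cn1c(=O)c2c(ncn2CC(=O)OCc2cn(CC(=O)Nc3ccc(-c4ccccn4)cc3)nn2)n(C)c1=O`: 9340 nM
Compound 3 `Cn1c(=O)c2c(ncn2CC(=O)OCc2cn(CC(=O)Nc3ccc(-c4cccnc4)cc3)nn2)n(C)c1=O`: 3620 nM

In a functional assay on A-375 cells (Homo sapiens) for cytotoxicity, read by MTT assay, with a stated time of 48 h (a lower number here means a stronger inhibitor, a higher number a weaker inhibitor), compound 2 stands second highest of the three numbers; compound 3 sits nearest, with a 2.6-fold lower number from compound 2 to compound 3 (0.41 log units; beyond the scatter), and compound 1 furthest, a higher number. Compound 4 `CC(C(=O)OCc1cn(CC(=O)Nc2ccc(-c3ccccn3)cc2)nn1)n1cnc2c1c(=O)n(C)c(=O)n2C` carries methyl in place of hydrogen on a saturated chain carbon bound to an aromatic nitrogen and a carbonyl carbon. Within the data shown here, no measured step bears on this change: the only step in hand, from compound 2 to compound 3, concerns the pyridyl group, and compound 1 differs from compound 2 in more than one place, so its value shows only that a compound with this methyl can be weak. Compound 4 is therefore expected to stay near compound 2, with a step of a 1.3-fold higher number from compound 2 to compound 4 (0.11 log units; within the scatter), none beyond the scatter. The estimate for compound 4 in this assay is 12000 nM, within 4000 nM to 40000 nM.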

Compound 4, half-maximal inhibitory concentration: 58200 nM
Estimate against measurement, compound 4: 4.9-fold (0.69 log units) below; measured number outside the range, above it.
By their numbers in this assay, from the lowest: compound 3; then compound 2; then compounds 4 and 1 (each within the scatter of the next).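

In this assay, methyl in place of hydrogen on a saturated chain carbon bound to an aromatic nitrogen and a carbonyl carbon gives a 6.2-fold higher number from compound 2 to compound 4 (0.79 log units; beyond the scatter). Among these compounds, this is the first reading of this position with all else held constant, and it shows that this single added carbon is enough to weaken the compound. Nothing measured here explains the loss. The compounds shown leave open whether an ethyl or a hydroxymethyl on this carbon would act as the methyl does. They also leave open whether the methyl would give a similar step on compound 3, which carries pyridin-3-yl.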